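Replacing a Cyclobutylcarbonyl Group with a Hydroxybutyl Chain

The compounds below may be only part of what the source reports. "The series", "measured", "known", "first", "only" and "open" are said of these compounds alone.

Measured compounds:
compound 1 `Cc1ccc(-c2cnc(N)nc2-c2ccccc2)cc1`, 51%
compound 2 `Nc1ncc(-c2ccc(F)cc2)c(-c2ccccc2)n1`, > 80%
compound 3 `O=C(Nc1ncc(-c2cccc(Cl)c2)c(-c2ccccc2)n1)C1CCC1`, 52%

In an assay on CHO cells for displacement of a labelled ligand from adenosine receptor A1 (Homo sapiens), read by scintillation counting, with a stated time of 1 h, tested at 1 uM (a lower number here means less inhibition, a higher number more inhibition at the concentration tested (going by the name of the read-out)), compound 3 gives 52%. Compound 1 sits 51%, within the usual scatter of compound 3. For compound 2 the reported > 80% is a limit of this assay, not a number. Compound 4 `OCCCCNc1ncc(-c2cccc(Cl)c2)c(-c2ccccc2)n1` differs from compound 3 by 4-hydroxybutyl in place of cyclobutylcarbonyl on a nitrogen on an aromatic ring. Within the data shown here, the only measured step, a number at least 29 percentage points higher from compound 1 to compound 2 (beyond the scatter), concerns a change on an aromatic carbon and so does not touch the nitrogen where compound 4 changes; no measured step bears directly on it. A step around the scatter is therefore expected, a number 7 percentage points lower from compound 3 to compound 4 (within the scatter). Compound 4 is estimated at 45%, between 15% and 75%.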

Compound 4, a percentage reported as inhibition, at one concentration (the size of the read-out at that concentration, not a potency): > 80%
Compound 4: no number, only a limit; the forecaster's own chance of this, stated with the estimate: 10%; at least 35 percentage points between middle value and limit.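

In this assay, the nitrogen on the aromatic ring proves to be a place where the attached group matters: 4-hydroxybutyl in place of cyclobutylcarbonyl brings a number at least 28 percentage points higher from compound 3 to compound 4 (beyond the scatter). Among these compounds, the earlier step concerned only an aromatic carbon, so this is the first measured change at this nitrogen. The reading for compound 4 is a limit of the assay, not a number, so the full size of the step stays unknown: the limit of > 80% in this assay, at which 2 of the 4 values shown sit.

The compounds shown leave open which part of the change carries the step: losing the carbonyl, losing the ring, or gaining the hydroxyl. A plain butyl group or a 4-aminobutyl chain on the same nitrogen would help separate these.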